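Aryl-triazole series on the bicyclic lactam core: compound 4

The compounds below may be only part of what the source reports. "The series", "measured", "known", "first", "only" and "open" are said of these compounds alone.

Measured so far in a functional assay on HepG2 cells (Homo sapiens) for inhibition, read by MTT assay, with a stated time of 24 h; on this read-out higher numbers stand for weaker inhibition and lower numbers for stronger inhibition:
compound 1 `CC1(C)[C@H]2CC[C@]1(C)N(Cc1cn(-c3cccc(F)c3)nn1)C(=O)C2` — 80 nM
compound 2 `CC1(C)[C@H]2CC[C@]1(C)N(Cc1cn(-c3ccc(O)cc3)nn1)C(=O)C2` — 80 nM
compound 3 `CC1(C)[C@H]2CC[C@]1(C)N(Cc1cn(-c3cccc(Br)c3)nn1)C(=O)C2` — 20 nM

Compound 2 sits level with compound 1 at the digits shown, the two together giving the highest numbers of the three; its only separation is from compound 3, seen in a 4.0-fold lower number from compound 2 to compound 3 (0.60 log units; beyond the scatter). The step from compound 1 to compound 3, a 4.0-fold lower number from compound 1 to compound 3 (0.60 log units; beyond the scatter), shows that exchanging a small for a larger group on the phenyl ring moved the number downward by a modest amount, while no change at the digits printed from compound 1 to compound 2 (within the scatter) shows no separation.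

Compound 4 `Cc1cccc(-n2cc(CN3C(=O)C[C@@H]4CC[C@@]3(C)C4(C)C)nn2)c1` is the next member. Its change from compound 2 is 3-methylphenyl in place of 4-hydroxyphenyl on an aromatic nitrogen. Going by the values given here, no measured step places a 3-methylphenyl on the aromatic nitrogen, so the bearing steps are only those around compound 2 and compound 3. Given that compound 3 with 3-bromophenyl gave 20 nM and compound 2 gave 80 nM, the expectation for compound 4 is a step of a 2.0-fold lower number from compound 2 to compound 4 (0.30 log units; within the scatter), a modest downward move. Compound 4 is thus estimated at 40 nM, within a range from 15 nM to 120 nM.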

Compound 4, half-maximal inhibitory concentration: 300 nM
For compound 4 the middle estimate is 7.5-fold (0.88 log units) below the measured one; the whole stated range lies below it.
By their numbers in this assay, from the lowest: compound 3; then compounds 1 and 2 (each within the scatter of the next); then compound 4.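

In this assay, the group on the phenyl ring at this aromatic nitrogen separates closely related compounds widely, with a 15-fold higher number from compound 3 to compound 4 (1.18 log units; beyond the scatter) the largest step in the set. Compound 4 also stands apart from the other two, with a 3.8-fold higher number from compound 1 to compound 4 (0.57 log units; beyond the scatter) and a 3.8-fold higher number from compound 2 to compound 4 (0.57 log units; beyond the scatter), so the downward move from 3-fluorophenyl to 3-bromophenyl does not carry over to 3-methylphenyl, and compound 4 has the highest number of the four. No supporting measurement accounts for this order.

Still open, on these data alone, is where 3-chlorophenyl or 3-aminophenyl would fall relative to the 3-bromophenyl and 3-methylphenyl compounds. The step to compound 4 from compound 2 also changes both the group and its place on the phenyl ring, so a 3-hydroxyphenyl or 4-methylphenyl partner would be needed to separate the two.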